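Iodo in Place of Thiophen-3-yl: Tolerated Concentration on HEL Cells

A few compounds are considered here, and "the series" means these few. Any claim that something is new, unique, unknown or untested is made for them only; others in the source may bear on it.

Of the compounds shown here, three have been tested in an ADME assay on HEL cells (Homo sapiens) for cytotoxicity, with a stated time of 3 days; a lower number here means that less compound is tolerated, a higher number that more compound is tolerated. Compound 1 `Cc1cc(-c2cccc(O)c2)c2ncc(CSCCc3ccccc3)n2c1` gives 20 ug/mL, and compound 2 `Cc1cc(-c2ccccc2)c2ncc(CSCCc3ccccc3)n2c1` gives 20 ug/mL; the step of no change at the digits printed from compound 1 to compound 2 (within the scatter) shows that the two lie together. Compound 3 `Cc1cc(-c2ccsc2)c2ncc(CSCCc3ccccc3)n2c1` gives 100 ug/mL, the highest of the three numbers; the steps of a 5.0-fold higher number from compound 1 to compound 3 (0.70 log units; beyond the scatter) and a 5.0-fold higher number from compound 2 to compound 3 (0.70 log units; beyond the scatter) are both beyond the scatter, so compound 3 stands apart from compounds 1 and 2 as the most tolerated of the three.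

Compound 4 `Cc1cc(I)c2ncc(CSCCc3ccccc3)n2c1` differs from compound 3 in one place: iodo in place of thiophen-3-yl on an aromatic carbon. The earlier steps all concern the same aromatic carbon, yet each exchanges one aryl or heteroaryl group for another; none replaces such a group by a single halogen atom, so they bear on compound 4 only as a guide to the size of change this position has shown, which was modest. Compound 4 is therefore expected to fall between the two groups of numbers seen so far, and the step of a 2.0-fold lower number from compound 3 to compound 4 (0.30 log units; within the scatter) is expected to run downward. The estimate for compound 4 is 50 ug/mL, with a range from 20 ug/mL to 100 ug/mL.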

Compound 4, minimum cytotoxic concentration: >= 4 ug/mL
Compound 4 gave a limit, no number; the forecaster's own chance of this, stated with the estimate: 15%; the middle value does not contradict the limit.
By their numbers in this assay, from the lowest: compounds 1 and 2 (each within the scatter of the next); then compound 3.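

In this assay compound 4 gives >= 4 ug/mL, which is a limit and not a number. The steps to compound 4 from compounds 1, 2 and 3 therefore cannot be read. The compounds shown leave open where compound 4 stands relative to compounds 1, 2 and 3.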